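From pentafluorophenyl to 4-cyanophenyl on the carbonyl carbon

The compounds below may be only part of what the source reports. "The series", "measured", "known", "first", "only" and "open" are said of these compounds alone.

Measured in a functional assay on DU-145 cells (Homo sapiens) for inhibition, read by trypan blue exclusion, with a stated time of 96 h; on this read-out lower numbers stand for stronger inhibition of growth and higher numbers for weaker inhibition of growth:
compound 1 `O=C(/C(=C\c1ccc(O)c([N+](=O)[O-])c1)SCc1ccc(Br)cc1)c1c(F)c(F)c(F)c(F)c1F` gives 10000 nM
compound 2 `O=C(/C(=C\c1ccc(O)c([N+](=O)[O-])c1)SCc1ccc(Cl)cc1)c1ccc(Cl)cc1` gives 10000 nM
compound 3 `O=C(/C(=C\c1ccc(O)c([N+](=O)[O-])c1)S(=O)(=O)Cc1ccc(Br)cc1)c1c(F)c(F)c(F)c(F)c1F` gives 50000 nM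

Compound 1 stands level with compound 2 at the digits reported, and the two share the lowest number of the three. Going by the values given here, the only measured step that changes a single place is a 5.0-fold higher number from compound 1 to compound 3 (0.70 log units; beyond the scatter) on exchanging (4-bromobenzyl)sulfanyl for (4-bromobenzyl)sulfonyl. That step is modest, though beyond the scatter.

Compound 4 `N#Cc1ccc(C(=O)/C(=C\c2ccc(O)c([N+](=O)[O-])c2)SCc2ccc(Br)cc2)cc1` keeps the core of compound 1 and alters only the group on the carbonyl carbon, where 4-cyanophenyl takes the place of 2,3,4,5,6-pentafluorophenyl: 4-cyanophenyl in place of 2,3,4,5,6-pentafluorophenyl on a carbonyl carbon. Among the compounds with values here, no measured step touches this place, so the sulfonyl exchange gives no direct measure of the change. It serves only as a guide to how wide the range should be. Compound 2 reads 10000 nM in this assay, the same number as compound 1, and nothing else in the data points either way. No shift beyond the scatter is therefore expected in this assay. The expected step is no change at the digits printed from compound 1 to compound 4 (within the scatter). For compound 4 the estimated value is 10000 nM, with an expected range from 3000 nM to 30000 nM.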

Compound 4, concentration for 50% growth inhibition: 10000 nM
The estimate for compound 4 equals the measured number at the digits printed; the range from low to high includes it.
By their numbers in this assay, from the lowest: compounds 1, 2 and 4 (each within the scatter of the next); then compound 3.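

Going by these compounds alone, with the step of no change at the digits printed from compound 1 to compound 4 (within the scatter) in this assay, the group on the carbonyl carbon has its first direct reading, since the only earlier single-place step concerned the sulfur-bearing (4-bromobenzyl) group. For this one pair, 4-cyanophenyl, which brings a triple bond and a hydrogen-bond acceptor, and 2,3,4,5,6-pentafluorophenyl, which has neither, give readings that lie within the scatter of each other, so the five fluorine atoms of compound 1 are not needed to keep its reading at this place. No measurement at hand speaks to the cause of this result.

The compounds shown leave open whether the same reading would hold for a group on the carbonyl carbon that has no aromatic ring, such as a piperidine or a short alkyl chain, or for a phenyl ring bearing a carboxylic acid or an amine. Going by these compounds, it also remains open whether exchanging (4-bromobenzyl)sulfanyl for (4-bromobenzyl)sulfonyl would have the same size of effect with 4-cyanophenyl on the carbonyl carbon as it has with 2,3,4,5,6-pentafluorophenyl.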